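Swapping 3-methylphenyl for 3-aminophenyl

This account rests on a few compounds, and the source may have more. Where it says the series, first, only, none or still open, it means among the compounds named here.

In a functional assay on U-251 cells (Homo sapiens) for antiproliferative activity, read by MTT assay, with a stated time of 48 h (a lower number here means a stronger inhibitor, a higher number a weaker inhibitor), compound 1 `COc1cc(-c2cccc3nc(-c4ccc(C)cc4)oc23)cc(OC)c1OC` gives 3200 nM. Compound 2 `COc1cc(-c2cccc3nc(-c4cccc(C)c4)oc23)cc(OC)c1OC` reaches only a limit of the assay, > 25000 nM. For the measured compounds named here, the one measured step, an at least 7.8-fold higher number from compound 1 to compound 2 (0.89 log units; beyond the scatter), lies beyond the scatter, but it does not test the new group. Compound 3 `COc1cc(-c2cccc3nc(-c4cccc(N)c4)oc23)cc(OC)c1OC` has amino in place of methyl on an aromatic carbon. With only the value of compound 1 at 3200 nM as a guide, a modest move toward a lower number is expected. A result at the limit of the assay remains possible for compound 3. The expected change is an at least 1.7-fold lower number from compound 2 to compound 3 (0.25 log units; that floor lies within the scatter). For compound 3 the estimate is 14000 nM, within 4000 nM to 30000 nM.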

Compound 3, half-maximal inhibitory concentration: 2200 nM
Beside the measured number, compound 3's estimate is 6.4-fold (0.80 log units) above it; the whole stated range lies above it.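

Compound 2 stands at a limit of the assay, > 25000 nM, so the size of the step from it is only a floor. In this assay, amino in place of methyl on this aromatic carbon, meta to a large group, gives an at least 11-fold lower number from compound 2 to compound 3 (1.05 log units; beyond the scatter), so a group at this position does not by itself leave a compound at the limit. The change of 3-aminophenyl for 4-methylphenyl gives a 1.5-fold lower number from compound 1 to compound 3 (0.16 log units; within the scatter), which does not tell those two compounds apart.

Still open, as far as these compounds go, is how 4-aminophenyl would compare with 3-aminophenyl on the shared core. From the compounds shown here alone, it is equally open whether a hydroxyl or a dimethylamino group in place of the amino would hold the value of compound 3.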